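This account rests on a few compounds, and the source may have more. Where it says the series, first, only, none or still open, it means among the compounds named here.

Three compounds from this series have so far been run in a functional assay, with a stated time of 20 min (a higher number here means a weaker inhibitor, a lower number a stronger inhibitor), and a fourth awaits its number.

Compound 1 `CCOC(=O)c1cnn(-c2nc(-c3ccccc3O)c(C#N)c(=O)n2C)c1N` carries a hydroxy on its phenyl ring; in this assay compound 1 gives 48 ug/mL. Compound 3 `CCOC(=O)c1cnn(-c2nc(-c3ccccc3Cl)c(C#N)c(=O)n2C)c1N` is the same molecule with chloro in place of hydroxy on an aromatic carbon; in this assay compound 3 gives 78 ug/mL, so that the step of a 1.6-fold higher number from compound 1 to compound 3 (0.21 log units; within the scatter) is a small rise that stays inside the usual spread of repeated runs.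

Compound 2 `Cn1c(NN)nc(-c2ccccc2O)c(C#N)c1=O` shares the hydroxyphenyl of compound 1 but rests on a different core; the difference between the two cores is not broken down here. In this assay compound 2 gives 38 ug/mL. Set beside compound 1, the two values of compound 2 and compound 1 lie within the scatter of each other; set beside compound 3, the value of compound 2 is separated by a gap that goes beyond it.

Compound 4 `Cn1c(NN)nc(-c2ccccc2Cl)c(C#N)c1=O` is the unmeasured partner of compound 2, made by chloro in place of hydroxy on an aromatic carbon, the same change that carries compound 1 into compound 3, and at the same kind of place on the ring. Among the measured compounds shown here, because the one measured example of this change, a 1.6-fold higher number from compound 1 to compound 3 (0.21 log units; within the scatter), moved the number only a little, the step expected from compound 2 to compound 4 is estimated as a 1.6-fold higher number from compound 2 to compound 4 (0.20 log units; within the scatter). For compound 4 in this assay the estimate is 60 ug/mL, expected to lie between 30 ug/mL and 120 ug/mL.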

Compound 4, half-maximal inhibitory concentration: 58 ug/mL
Compound 4: middle estimate off by 1.0-fold (0.01 log units), on the high side, and the stated range covers the measured number.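

In this assay, chloro in place of hydroxy on an aromatic carbon gives a 1.5-fold higher number from compound 2 to compound 4 (0.18 log units; within the scatter), so on the core of compound 2 the replacement leaves the number inside the usual spread of repeated runs. Set beside the earlier step, the change reads alike on both cores: the same change on two cores in this assay, a 1.6-fold higher number (0.21 log units; within the scatter) from compound 1 to compound 3 and a 1.5-fold higher number (0.18 log units; within the scatter) from compound 2 to compound 4, 1.1-fold (0.03 log units) apart, within the scatter of two such steps. Among the compounds shown here, for these two pairs and at this one place on the ring, the step carried over from one core to the other, but since both steps lie within the scatter, this shows only that the change did little on either core, and two pairs in one assay establish no rule for the series or for any further core.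

The compounds shown leave open whether another group at the same place, such as a methoxy, a fluoro or an amine, would carry across the two cores in the same way. They also leave open how the pairs would read with other changes elsewhere on the molecule, such as a carboxylic acid in place of the ethyl ester of compound 1 and compound 3, or a longer chain in place of the methyl shared by all four compounds.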